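The source may report more compounds than this note shows. Statements on the series, on what has been measured and on what is new or still open speak of the compounds shown alone.

Measured so far:
Compound 1 `CSc1ncc(C2C(C(=O)OCc3ccccc3)=C(C)NC(C)=C2C(=O)OCc2ccccc2)n1Nc1ccccc1` gives 1.49 nM in an assay on isolated protein (strain albino) for antagonist activity at Voltage-dependent L-type calcium channel subunit alpha-1C (Cavia porcellus); a higher number here means a weaker inhibitor, a lower number a stronger inhibitor.
Compound 2 `COC(=O)C1=C(C)NC(C)=C(C(=O)OCc2ccccc2)C1c1cnc(SC)n1Nc1ccccc1` gives 2.21 nM in this assay.

Compound 2 has the highest of these two numbers, with compound 1 nearest, but the two lie within the scatter of each other, so neither can be called the stronger or weaker inhibitor. Among the compounds with values here, the single measured step that connects them, a 1.5-fold higher number from compound 1 to compound 2 (0.17 log units; within the scatter), is a change at the ester: hydrogen in place of phenyl on a saturated chain carbon bound to an oxygen next to a carbonyl group, and the number hardly moved.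

Compound 3 `CCOC(=O)C1=C(C)NC(C)=C(C(=O)OCc2ccccc2)C1c1cnc(SC)n1Nc1ccccc1` has not been measured. Within the data shown here, it differs from compound 2 by methyl in place of hydrogen on a saturated chain carbon bound to an oxygen next to a carbonyl group, a change at the same place as the one measured step. Since removing a phenyl there gave only a 1.5-fold higher number from compound 1 to compound 2 (0.17 log units; within the scatter), adding a single carbon at that place is expected to move the number no further than the scatter, so the expected step of a 1.1-fold lower number from compound 2 to compound 3 (0.04 log units; within the scatter) is essentially none. Compound 3 is therefore estimated at about 2 nM, with a likely range from 0.9 nM to 4.5 nM.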

Compound 3, half-maximal inhibitory concentration: 1.86 nM
Estimate against measurement, compound 3: 1.1-fold (0.03 log units) above, and the stated range covers the measured number.
By their numbers in this assay, from the lowest: compounds 1, 3 and 2 (each within the scatter of the next).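

A third group now sits on the saturated chain carbon bound to an oxygen next to a carbonyl group, and in this assay the change from hydrogen to methyl is a 1.2-fold lower number from compound 2 to compound 3 (0.07 log units; within the scatter) while the change from phenyl to methyl is a 1.2-fold higher number from compound 1 to compound 3 (0.10 log units; within the scatter). Where the earlier pair offered only one comparison at this place, hydrogen, methyl and phenyl now form a set of three whose numbers cannot be told apart, and none of the three compounds goes against that reading. Nothing measured here gives a reason for this flat result.

These three compounds carry only hydrogen, methyl or phenyl at this place, so they cannot show whether an amine, a carboxylic acid or a longer chain such as butyl there would leave the number just as unmoved. They also share everything else in the core of compound 1, so they say nothing about how much a change elsewhere in the structure would matter.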